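This account rests on a few compounds, and the source may have more. Where it says the series, first, only, none or still open, it means among the compounds named here.

Measured so far:
compound 1 `COc1cc2ncnc(Nc3ccc(C)cc3)c2cc1OCCCCC(=O)Nc1ccc(S(N)(=O)=O)cc1` — 35500 nM
compound 2 `CCc1ccc(Nc2ncnc3cc(OC)c(OCCCCC(=O)Nc4ccc(S(N)(=O)=O)cc4)cc23)cc1` — 7220 nM
compound 3 `C#Cc1cccc(Nc2ncnc3ccc(NC(=S)Nc4ccc(S(N)(=O)=O)cc4)cc23)c1` — 15300 nM

All numbers come from a functional assay on A-431 cells (Homo sapiens) for antiproliferative activity, read by MTT assay, with a stated time of 72 h; on this read-out higher numbers stand for weaker inhibition and lower numbers for stronger inhibition. Compound 3 stands second highest of the three: compound 2 gives a lower number and compound 1 a higher one, both gaps beyond the scatter. Within the data shown here, no single-point step links compound 3 to either of them, so only the two values themselves can be set side by side.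

Compound 4 `NS(=O)(=O)c1ccc(NC(=S)Nc2ccc3ncnc(Nc4ccc(F)c(Br)c4)c3c2)cc1` is derived from compound 3 by one change: 3-bromo-4-fluorophenyl in place of 3-ethynylphenyl on a nitrogen on an aromatic ring. Among the measured compounds shown here, the only step measured in one place is a 4.9-fold lower number from compound 1 to compound 2 (0.69 log units; beyond the scatter), a change on a chain carbon in another part of the molecule, which says nothing about swapping one aryl group for another on the nitrogen. For the measured compounds named here, no measured pair shows a change of this kind, so the expectation rests on the absence of evidence for movement.

For compound 4 the expected step is a 1.3-fold lower number from compound 3 to compound 4 (0.11 log units; within the scatter), which lies within the scatter. Compound 4 is therefore expected to give 12000 nM in this assay, with a range from 3000 nM to 50000 nM.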

Compound 4, half-maximal inhibitory concentration: 18200 nM
Compound 4: middle estimate off by 1.5-fold (0.18 log units), on the low side; the range from low to high includes it.
By their numbers in this assay, from the lowest: compound 2; then compounds 3, 4 and 1 (each within the scatter of the next, the first and the last beyond it).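

In this assay, 3-bromo-4-fluorophenyl in place of 3-ethynylphenyl on a nitrogen on an aromatic ring gives a 1.2-fold higher number from compound 3 to compound 4 (0.08 log units; within the scatter), the first step read at this position. A triple bond outside aromatic rings leaves and fluorine and bromine enter, yet the two aryl groups cannot be told apart on this read-out, so this position tolerates at least this one exchange with the rest of compound 3 unchanged. Nothing available bears on why the step is this small.

Going by these compounds, whether an unsubstituted phenyl, a cyclohexyl or a benzyl group on this nitrogen would move the number beyond the scatter remains open. On these data alone, it is also open whether the same exchange would give a similar step on the core of compound 2, which carries a different chain.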